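The compounds below may be only part of what the source reports. "The series", "measured", "known", "first", "only" and "open" are said of these compounds alone.

Measured so far:
compound 1 `CCOc1cccc(Nc2nc3nonc3nc2Nc2cccc(OCC)c2)c1` — 10100 nM
compound 2 `Fc1cccc(Nc2nc3nonc3nc2Nc2ccccc2F)c1` — 190 nM
compound 3 `COc1ccc(Nc2nc3nonc3nc2Nc2ccccc2F)cc1` — 1600 nM

In an assay on mitochondria from L6 cells (Rattus norvegicus) for activation, with a stated time of 90 min (on this read-out higher numbers stand for an effect only at larger amounts of compound and lower numbers for an effect already at smaller amounts), compound 3 gives the second highest of the three numbers, above compound 2 and below compound 1. Compound 4 `CCOc1cccc(Nc2nc3nonc3nc2Nc2ccccc2F)c1` differs from compound 3 by 3-ethoxyphenyl in place of 4-methoxyphenyl on a nitrogen on an aromatic ring. Among the measured compounds shown here, no measured step covers this exact exchange. For the measured compounds named here, the single recorded step, an 8.4-fold higher number from compound 2 to compound 3 (0.93 log units; beyond the scatter), shows that changing this aryl group can move the number well beyond the scatter, and compound 1, which carries two 3-ethoxyphenyl groups, gives the highest number of all. On that basis a modest rise is expected for compound 4, with a 1.8-fold higher number from compound 3 to compound 4 (0.24 log units; within the scatter). Compound 4 is therefore estimated at 2800 nM, within a range of 800 nM to 9000 nM.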

Compound 4, half-maximal effective concentration: 2200 nM
Compound 4: middle estimate off by 1.3-fold (0.10 log units), on the high side; the range from low to high includes it.
By their numbers in this assay, from the lowest: compound 2; then compounds 3 and 4 (each within the scatter of the next); then compound 1.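

In this assay, 3-ethoxyphenyl in place of 4-methoxyphenyl on a nitrogen on an aromatic ring leaves the number within the scatter (a 1.4-fold higher number from compound 3 to compound 4 (0.14 log units; within the scatter)), so this exchange does not separate the two groups. Ethoxy in place of fluoro on an aromatic carbon has a much larger effect (a 12-fold higher number from compound 2 to compound 4 (1.06 log units; beyond the scatter)), and 2-fluorophenyl in place of 3-ethoxyphenyl also goes beyond the scatter (a 4.6-fold lower number from compound 1 to compound 4 (0.66 log units; beyond the scatter)). Nothing available here accounts for these differences. The compounds shown leave open how an amine or a carboxylic acid in place of the ethoxy group would read, and whether a longer chain there would behave like ethoxy.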